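Pyridin-3-yl for 4-methoxyphenyl on the cyclopropane

A few compounds are considered here, and "the series" means these few. Any claim that something is new, unique, unknown or untested is made for them only; others in the source may bear on it.

Measured so far:
compound 1, `CC(C)[C@H](N)CN(C(=O)[C@@H]1C[C@H]1c1ccccc1)c1ccc(-c2ccccc2)cc1`, 1.1 nM
compound 2, `CC[C@H](C)[C@H](N)CN(C(=O)[C@@H]1C[C@H]1c1ccc(OC)cc1)c1ccc(-c2ccccc2)cc1`, > 25000 nM

Two compounds of the series have been run in a functional assay for agonist activity at G protein-coupled receptor 88 (Homo sapiens), read by HTRF and cAMP accumulation; a lower number here means that less compound is needed, a higher number that more compound is needed for the effect. Compound 1 gives 1.1 nM. Compound 2 gives only a limit of the assay, > 25000 nM, so no number is known for it; this is the situation of the limit of > 25000 nM in this assay, at which 1 of the 2 values shown sits. Among the compounds with values here, compound 1 and compound 2 differ in more than one place, so the two values show only that one compound is potent and the other reaches no measurable effect.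

Compound 3, `CC[C@H](C)[C@H](N)CN(C(=O)[C@@H]1C[C@H]1c1cccnc1)c1ccc(-c2ccccc2)cc1`, is the next to be measured in this assay. It differs from compound 2 by pyridin-3-yl in place of 4-methoxyphenyl on a saturated ring carbon. Compound 3 carries the same amine side chain as compound 2, and whether the aryl group or that side chain holds compound 2 above the limit cannot be told from the two values. The change from compound 2 to compound 3 is expected to give a step of an at least 5.0-fold lower number from compound 2 to compound 3 (0.69 log units; beyond the scatter), downward, but with a real chance that compound 3 also stays at the limit. Compound 3 is estimated at 5000 nM, within 200 nM to 25000 nM.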

Compound 3, half-maximal effective concentration: 1500 nM
Compound 3: the middle estimate sits 3.3-fold (0.52 log units) above what was measured; measured number inside the range.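

In this assay, the group on the cyclopropane is now seen to decide the read-out on its own, with the amine side chain unchanged: pyridin-3-yl in place of 4-methoxyphenyl gives an at least 16-fold lower number from compound 2 to compound 3 (1.22 log units; beyond the scatter). The amine side chain is shared by the pair, and compound 3, which carries it, gives 1500 nM. That side chain therefore does not by itself hold a compound at the limit. The size of the step is only a bound and not a measured number, because compound 2 stands at a limit of the assay: the limit of > 25000 nM in this assay, at which 1 of the 3 values shown sits.

Within the data shown here, compound 1 and compound 3 differ in both the amine side chain and the group on the cyclopropane, so their values give no step and the two places cannot be weighed against each other. Also open, going by these compounds, is whether the gain follows from the ring nitrogen of pyridin-3-yl or from the loss of the methoxy group, which a group such as 4-fluorophenyl, pyridin-4-yl or 6-methoxypyridin-3-yl on the cyclopropane would help to separate.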